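This account rests on a few compounds, and the source may have more. Where it says the series, first, only, none or still open, it means among the compounds named here.

Working notes on the series.

Three compounds sharing one core have numbers in an assay on LtK cells with ATP-sensitive inward rectifier potassium channel 11 (Homo sapiens) as the target; a lower number here means that less compound is needed, a higher number that more compound is needed for the effect. Compound 1 `Cc1cccc(C(=O)Nc2c(C(O)(C(F)(F)F)C(F)(F)F)ccc3ccccc23)c1` gives 23 nM. Compound 2 `N#Cc1cccc(C(=O)Nc2c(C(O)(C(F)(F)F)C(F)(F)F)ccc3ccccc23)c1` gives 12 nM. Compound 3 `O=C(Nc1c(C(O)(C(F)(F)F)C(F)(F)F)ccc2ccccc12)c1cccc([N+](=O)[O-])c1` gives 117 nM, the highest of the three: the nearest is compound 1 with a 5.1-fold higher number from compound 1 to compound 3 (0.71 log units; beyond the scatter), the furthest compound 2 with a 9.8-fold higher number from compound 2 to compound 3 (0.99 log units; beyond the scatter). Between compound 1 and compound 2 the step is a 1.9-fold lower number from compound 1 to compound 2 (0.28 log units; within the scatter).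

Compound 4 `O=C(Nc1c(C(O)(C(F)(F)F)C(F)(F)F)ccc2ccccc12)c1ccc(Br)cc1` is not yet measured. Its change from compound 3 is 4-bromophenyl in place of 3-nitrophenyl on a carbonyl carbon. Among the compounds with values here, the steps that bear on it are the two that lead to the nitro compound: from compound 1, a methyl analogue with no hydrogen-bond acceptors on that ring, the number rises modestly, and from compound 2 it rises somewhat more. Compound 4 likewise carries a ring with no hydrogen-bond acceptors, so a modest step downward in this assay is expected, roughly back to the level of compound 1. The expected step is a 3.9-fold lower number from compound 3 to compound 4 (0.59 log units; beyond the scatter). For compound 4 the estimate is 30 nM with a range of 10 nM to 100 nM.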

Compound 4, half-maximal effective concentration: 47 nM
Compound 4: middle estimate off by 1.6-fold (0.19 log units), on the low side; measured number inside the range.
By their numbers in this assay, from the lowest: compounds 2 and 1 (each within the scatter of the next); then compound 4; then compound 3.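

In this assay, within the data shown here, the carbonyl carbon carries a 4-bromophenyl group for the first time, and replacing 3-nitrophenyl with it gives a 2.5-fold lower number from compound 3 to compound 4 (0.40 log units; beyond the scatter) while still not matching the other two groups, with a 2.0-fold higher number from compound 1 to compound 4 (0.31 log units; beyond the scatter) and a 3.9-fold higher number from compound 2 to compound 4 (0.59 log units; beyond the scatter) as the remaining steps. The absence of hydrogen-bond acceptors therefore does not set the number on its own: 4-bromophenyl has none, yet 3-cyanophenyl in compound 2 gives the lower number, and compound 2 goes against any ordering by acceptor count. No evidence at hand accounts for these steps.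

The swap changes both the substituent and its printed ring number, so 3-bromophenyl and 4-methylphenyl analogues would be needed to separate the two. Going by these compounds, how an amine or a carboxylic acid on this ring would read remains open.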